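Pyridin-2-yl replacing furan-2-yl on the bis(hydroxyphenyl)pyridine core

The source may report more compounds than this note shows. Statements on the series, on what has been measured and on what is new or still open speak of the compounds shown alone.

Measured compounds:
Compound 1 `Oc1ccccc1-c1cc(-c2ccsc2)cc(-c2ccccc2O)n1`: in a functional assay on T47D cells (Homo sapiens) for cytotoxicity, read by CCK-8 assay (on this read-out higher numbers stand for weaker inhibition and lower numbers for stronger inhibition), compound 1 gives > 50000 nM, a limit of the assay.
Compound 2 `Oc1ccccc1-c1cc(-c2ccco2)cc(-c2ccccc2O)n1`: compound 2 gives > 50000 nM, also a limit of the assay.
Compound 3 `Oc1cccc(-c2cc(-c3ccco3)cc(-c3ccccc3O)n2)c1`: compound 3 gives 820 nM.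

Compound 2 thus stands only at a limit; it shares the limit with compound 1 (the limit of > 50000 nM in this assay, at which 2 of the 3 values shown sit). Compound 4 `Oc1ccccc1-c1cc(-c2ccccn2)cc(-c2ccccc2O)n1` differs from compound 2 by pyridin-2-yl in place of furan-2-yl on an aromatic carbon, that is, a six-membered aromatic ring with 1 hetero atom instead of a five-membered one, opposite the ring nitrogen. For the measured compounds named here, no measured step tests this exchange: a step that the two limits leave unreadable from compound 1 to compound 2 leaves the effect of varying the five-membered ring unreadable, and an at least 60-fold lower number from compound 2 to compound 3 (1.78 log units; beyond the scatter) concerns a different position. No step beyond the scatter is therefore expected, most likely again a limit. Compound 4 is estimated at 50000 nM, within 15000 nM to 150000 nM. The expected step is a number no higher from compound 2 to compound 4 (the limit leaves the size open).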

Compound 4, half-maximal inhibitory concentration: > 50000 nM
Compound 4 was reported as a limit; the forecaster's own chance of this, stated with the estimate: 70%; the middle value sits exactly at the limit.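

In this assay compound 4 is again a limit, so the steps among compound 1, compound 2 and compound 4 cannot be read: the limit of > 50000 nM in this assay, at which 3 of the 4 values shown sit.

The compounds shown leave open whether the group opposite the ring nitrogen changes the read-out at all.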